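This account rests on a few compounds, and the source may have more. Where it says the series, first, only, none or still open, it means among the compounds named here.

Working notes on the series, read in a toxicity assay (LMTK cells) for cytotoxicity, with Mus musculus as the target, read by MTT assay, with a stated time of 72 h; on this read-out lower numbers stand for stronger inhibition and higher numbers for weaker inhibition. Compound 3 `Cc1c(C)c2c(c(C)c1OC(=O)CCC(=O)O)CCC(C)(C(=O)NCC1CC(C)(C)N([O])C1(C)C)O2` gives > 300000 nM, which is a limit of the assay and not a number. Compound 1 `Cc1c(C)c2c(c(C)c1OC(=O)CCC(=O)O)CCC(C)(C(=O)NC1CC(C)(C)N([O])C(C)(C)C1)O2` gives > 300000 nM, again only a limit. Compound 2 `Cc1c(C)c2c(c(C)c1O)CCC(C)(C(=O)NC1CC(C)(C)N([O])C(C)(C)C1)O2` gives a measured 252000 nM.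

The next structure is compound 4 `Cc1c(C)c2c(c(C)c1O)CCC(C)(C(=O)NCC1CC(C)(C)N([O])C1(C)C)O2`, which differs from compound 3 as follows: hydrogen in place of (2-carboxyethyl)carbonyl on an oxygen on an aromatic ring. For the measured compounds named here, the closest precedent is the same exchange with the other amide substituent, an at least 1.1-fold lower number from compound 1 to compound 2 (0.07 log units; that floor lies within the scatter). That floor does not show how large the true step is. The remaining comparison, a step that the two limits leave unreadable from compound 1 to compound 3, gives no size for the change of amide substituent.

In this assay, a small move towards lower numbers is therefore expected, with nothing beyond the scatter to be relied on, and compound 4 may also stop at the limit. The step expected from the estimate is an at least 1.2-fold lower number from compound 3 to compound 4 (0.09 log units; that floor lies within the scatter). For compound 4 the expected value is 240000 nM, with an estimated range of 130000 nM to 300000 nM.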

Compound 4, half-maximal inhibitory concentration: 300000 nM
For compound 4 the middle estimate is 1.3-fold (0.10 log units) below the measured one; low and high end bracket the measured number.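

In this assay, the exchange on the other amide substituent gives a number no higher from compound 3 to compound 4 (the limit leaves the size open). The exchange now has a second case, and neither case gives a readable size: the same change on two cores in this assay, an at least 1.1-fold lower number (0.07 log units; that floor lies within the scatter) from compound 1 to compound 2 and a number no higher (the limit leaves the size open) from compound 3 to compound 4; the limit leaves it open whether they differ

For the compounds shown here, with hydroxy on the ring, the comparison of amide substituents can be read for the first time: compound 2 gives 252000 nM and compound 4 gives 300000 nM, two values within the scatter of each other, so the five-membered and six-membered rings are not told apart here. The values shown gather at a single limit: the limit of > 300000 nM in this assay, at which 2 of the 4 values shown sit.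

From the compounds shown here alone, the true size of the exchange stays open on both amide substituents. Also open, going by these compounds, is how the number would respond to an amine or a longer alkyl chain on this oxygen on the aromatic ring.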